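Difluoromethoxy for methoxy: a change made twice in the series

This account rests on a few compounds, and the source may have more. Where it says the series, first, only, none or still open, it means among the compounds named here.

Compound 3 `COc1ccc2[nH]c(S(=O)(=O)Cc3ccc(OCc4ncc(C)c(OC)c4C)c(OC)c3)nc2c1` gives 1210 nM in a functional assay on cells (Erythrocyte, Homo sapiens); a lower number here means a stronger inhibitor, a higher number a weaker inhibitor. Compound 1 `COc1cc(CS(=O)(=O)c2nc3cc(OC(F)F)ccc3[nH]2)ccc1OCc1ncc(C)c(OC)c1C` gives 1420 nM in this assay; the change from compound 3 is difluoromethyl in place of methyl on an oxygen on an aromatic ring, and the step is a 1.2-fold higher number from compound 3 to compound 1 (0.07 log units; within the scatter). Compound 2 `COc1ccc2[nH]c(S(=O)(=O)Cc3ccc(OCc4nccc(OCC(F)(F)F)c4C)c(OC)c3)nc2c1` gives 1760 nM in this assay; the difference between the cores of compound 2 and compound 3 is not broken down here, and the two values lie within the scatter of each other. Compound 4 `COc1cc(CS(=O)(=O)c2nc3cc(OC(F)F)ccc3[nH]2)ccc1OCc1nccc(OCC(F)(F)F)c1C` is not yet measured; it differs from compound 2 by difluoromethyl in place of methyl on an oxygen on an aromatic ring, the same change as from compound 3 to compound 1, at a place described in the same words. Resting on a 1.2-fold higher number from compound 3 to compound 1 (0.07 log units; within the scatter), the step expected for compound 4 is a 1.2-fold higher number from compound 2 to compound 4 (0.08 log units; within the scatter). Compound 4 is thus estimated at 2100 nM, between 1200 nM and 3800 nM.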

Compound 4, half-maximal inhibitory concentration: 1880 nM
Beside the measured number, compound 4's estimate is 1.1-fold (0.05 log units) above it; measured number inside the range.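

Difluoromethoxy for methoxy on the second core gives a 1.1-fold higher number from compound 2 to compound 4 (0.03 log units; within the scatter) in this assay. Set beside the first case, the change reads alike on the two cores: the same change on two cores in this assay, a 1.2-fold higher number (0.07 log units; within the scatter) from compound 3 to compound 1 and a 1.1-fold higher number (0.03 log units; within the scatter) from compound 2 to compound 4, 1.1-fold (0.04 log units) apart, within the scatter of two such steps. The change can thus be carried between these two cores with no step beyond the scatter in this assay, but two pairs show neither a gain nor a loss from it, and they set no rule for any other core in the series.

Open, on these data alone, is how the number responds to other groups on that oxygen, such as trifluoromethyl or a longer chain, or to an amine in place of the methoxy. Also open, as far as these compounds go, is whether the same holds in any read-out other than this assay.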